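Half-life of two benzylamine ester pairs

This account rests on a few compounds, and the source may have more. Where it says the series, first, only, none or still open, it means among the compounds named here.

Compound 1 `CCCN(CCC)Cc1cccc(C(=O)OCCOCn2cnc3c(=O)[nH]c(N)nc32)c1` gives 0.0133 h in an ADME assay on a cell-free system (plasma, Homo sapiens) for metabolic stability; on this read-out lower numbers stand for a shorter-lived compound and higher numbers for a longer-lived compound.
Compound 2 `CN(C)Cc1cccc(C(=O)OCCOCn2cnc3c(=O)[nH]c(N)nc32)c1` gives 0.117 h in this assay.
Compound 3 `CCCN(CCC)Cc1ccc(C(=O)OCCOCn2cnc3c(=O)[nH]c(N)nc32)cc1` gives 0.15 h in this assay.

Compound 1 and compound 2 share one core; the difference between that core and the core of compound 3 is not broken down here. Within the first pair, the change dimethylamino in place of dipropylamino on a saturated chain carbon bound to an aromatic carbon gave an 8.8-fold higher number from compound 1 to compound 2 (0.94 log units; beyond the scatter). Compound 4 `CN(C)Cc1ccc(C(=O)OCCOCn2cnc3c(=O)[nH]c(N)nc32)cc1` carries the same change on the core of compound 3, namely (dimethylamino in place of dipropylamino on a saturated chain carbon bound to an aromatic carbon), at the same place. Compound 3 and compound 2 lie within the scatter of each other, so the new core offers no separate hint of its own. Resting on the step of an 8.8-fold higher number from compound 1 to compound 2 (0.94 log units; beyond the scatter), compound 4 is expected to show a 4.0-fold higher number from compound 3 to compound 4 (0.60 log units; beyond the scatter) in this assay, though the step is carried over from one pair only and may not repeat in full. Compound 4 is estimated at 0.6 h, between 0.15 h and 2.5 h.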

Compound 4, half-life: 0.55 h
For compound 4 the middle estimate is 1.1-fold (0.04 log units) above the measured one; measured number inside the range.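

In this assay, dimethylamino in place of dipropylamino on the second core gave a 3.7-fold higher number from compound 3 to compound 4 (0.56 log units; beyond the scatter), so the number rose on this core as it had on the first. Set side by side, the two steps do not differ beyond what repeated measurements would allow: the same change on two cores in this assay, an 8.8-fold higher number (0.94 log units; beyond the scatter) from compound 1 to compound 2 and a 3.7-fold higher number (0.56 log units; beyond the scatter) from compound 3 to compound 4, 2.4-fold (0.38 log units) apart, within the scatter of two such steps This shows that the change carried from one core to the other in direction and, within the scatter, in size, but it rests on only two pairs and does not show that the step would hold on any further core.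

The compounds shown leave open where diethylamino or a ring amine such as piperidine would fall on either core. They also leave open whether a primary amine would continue the same trend.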